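The source may report more compounds than this note shows. Statements on the series, on what has been measured and on what is new or still open speak of the compounds shown alone.

Compound 1 `COc1ccc(-c2csc(N3N=C(c4ccc(C)cc4)CC3c3ccc4c(c3)OCCO4)n2)cc1` in a functional assay on B16-F10 cells (Mus musculus) for antiproliferative activity, read by MTT assay, with a stated time of 48 h (a higher number here means a weaker inhibitor, a lower number a stronger inhibitor), gives 2870 nM. Compound 2 `Cc1ccc(C2=NN(c3nc(-c4ccc(Br)cc4)cs3)C(c3ccc4c(c3)OCCO4)C2)cc1` gives 1680 nM and compound 3 `Clc1ccc(C2=NN(c3nc(-c4ccc(Br)cc4)cs3)C(c3ccc4c(c3)OCCO4)C2)cc1` gives 2150 nM; neither is set apart from compound 1 beyond the scatter, as a 1.7-fold lower number from compound 1 to compound 2 (0.23 log units; within the scatter) and the gap to compound 3 show. Compound 4 `COc1ccc(-c2csc(N3N=C(c4ccc(Br)cc4)CC3c3ccc4c(c3)OCCO4)n2)cc1` differs from compound 1 by bromo in place of methyl on an aromatic carbon. The step closest to this change is a 1.3-fold higher number from compound 2 to compound 3 (0.11 log units; within the scatter), a chloro for a methyl on an aromatic carbon; a 1.7-fold lower number from compound 1 to compound 2 (0.23 log units; within the scatter) is a bromo for a methoxy. Both sit within the scatter, so no step beyond the scatter is expected in this assay. Compound 4 is therefore estimated at 2500 nM, with a range from 1200 nM to 5200 nM. That estimate means a 1.1-fold lower number from compound 1 to compound 4 (0.06 log units; within the scatter) is expected.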

Compound 4, half-maximal inhibitory concentration: 1120 nM
Compound 4: middle estimate off by 2.2-fold (0.35 log units), on the high side; the measured number lies below the stated range.
By their numbers in this assay, from the lowest: compounds 4, 2, 3 and 1 (each within the scatter of the next, the first and the last beyond it).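

In this assay, among the compounds shown here, the change from 4-methylphenyl to 4-bromophenyl gives a 2.6-fold lower number from compound 1 to compound 4 (0.41 log units; beyond the scatter) and is the first single change to pass the scatter. The earlier change at this position, chloro in place of methyl, gave only a 1.3-fold higher number from compound 2 to compound 3 (0.11 log units; within the scatter), so this position can respond to a single-atom swap, at least with bromo and with the methoxy group kept on the other ring. No measurement available here accounts for the step.

Open, going by these compounds, is whether a fluoro, a nitrile or an amine at this position would move the number, and whether the bromo step holds in other compounds.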